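Methoxy in place of tert-butyl on a sulfonamide

A few compounds are considered here, and "the series" means these few. Any claim that something is new, unique, unknown or untested is made for them only; others in the source may bear on it.

Measured compounds:
compound 1, `CC(C)(C)c1ccc(NS(=O)(=O)c2ccc(N3CCNC3=O)cc2)cc1`, > 1000 nM
compound 2, `O=C1NCCN1c1ccc(S(=O)(=O)Nc2ccc3c(c2)CCC3)cc1`, 190 nM

In a functional assay on HT-29 cells (Homo sapiens) for antiproliferative activity, read by sulforhodamine B assay, with a stated time of 48 h (on this read-out higher numbers stand for weaker inhibition and lower numbers for stronger inhibition), compound 1 gives only a limit of the assay, > 1000 nM, and no number is known for it. This is the limit of > 1000 nM in this assay, at which 1 of the 2 values shown sits. In this assay compound 2 gives 190 nM. Compound 3, `COc1ccc(NS(=O)(=O)c2ccc(N3CCNC3=O)cc2)cc1`, has not been measured. It differs from compound 1 by methoxy in place of tert-butyl on an aromatic carbon. Within the data shown here, no pair of measured compounds shows how such a change plays out in this assay, and compound 1 itself offers no number to step from. Compound 3 is expected to remain weak, with an estimated step that the limit leaves unreadable from compound 1 to compound 3 that is not expected to lie clearly beyond the scatter. Compound 3 is therefore estimated at 1500 nM, in a range of 300 nM to 8000 nM, with a fair chance that the assay again reports only a limit.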

Compound 3, half-maximal inhibitory concentration: 800 nM
For compound 3 the middle estimate is 1.9-fold (0.27 log units) above the measured one; measured number inside the range.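

Methoxy on this aromatic carbon, para to a large group, gives the first actual number for this substitution pattern: in this assay compound 3 gives 800 nM. Compound 1 offered only a limit. The exchange of tert-butyl for methoxy can be read only as an at least 1.2-fold lower number from compound 1 to compound 3 (0.09 log units; that floor lies within the scatter), so the data show no gain beyond the scatter, though they do not rule one out. The true size of the step stays unknown because compound 1 rests at a limit: the limit of > 1000 nM in this assay, at which 1 of the 3 values shown sits.

Going by these compounds, whether an amine, a hydroxyl or a longer chain such as ethoxy at this same carbon would move the number clearly beyond the scatter stays open. Compound 2, at 190 nM, is not a one-place step from compound 3, so it says nothing about this change.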